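Formyl in Place of Hydrogen on a Ring Nitrogen

A few compounds are considered here, and "the series" means these few. Any claim that something is new, unique, unknown or untested is made for them only; others in the source may bear on it.

Compound 3 `Cc1ccc(C2=NNC(c3cn(-c4ccccc4)nc3-c3ccc(Cl)c(Cl)c3)C2)cc1` gives 48.4% in a functional assay on the whole organism (strain Wistar) for inhibition, with Rattus norvegicus as the target, read by paw edema, with stated times of 30 min and 120 min, at a dose of 50 mg/kg by the oral route (a higher number here means more inhibition at the dose given (going by the name of the read-out), a lower number less inhibition), the smallest of the three numbers shown, though its gap to compound 2 lies within the usual scatter. Compound 1 `CC(=O)N1N=C(c2ccc(C)cc2)CC1c1cn(-c2ccccc2)nc1-c1ccc(Cl)c(Cl)c1` gives 70.3%, and compound 2 `O=CN1N=C(c2ccc(Cl)cc2)CC1c1cn(-c2ccccc2)nc1-c1ccc(Cl)c(Cl)c1` gives 57.8%. Compound 4 `Cc1ccc(C2=NN(C=O)C(c3cn(-c4ccccc4)nc3-c3ccc(Cl)c(Cl)c3)C2)cc1` differs from compound 3 in one place: formyl in place of hydrogen on an amine nitrogen in a ring. Going by the values given here, the one measured step of a related kind runs the opposite way, where hydrogen replacing acetyl brought a number 21.9 percentage points lower from compound 1 to compound 3 (beyond the scatter). Compound 2 also carries a formyl, but differs from compound 4 elsewhere as well, so its value is only a hint. A formyl entering is therefore expected to raise the number beyond the scatter. Compound 4 is expected to give 60%, between 48% and 72%. That estimate means an expected step of a number 11.6 percentage points higher from compound 3 to compound 4 (beyond the scatter).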

Compound 4, a percentage reported as inhibition, in the whole organism at one dose (the size of the read-out at that dose, not a potency): 60.9%
Compound 4: middle estimate off by 0.9 percentage points, on the low side; the measured number falls inside the stated range.
By their numbers in this assay, from the lowest: compounds 3, 2, 4 and 1 (each within the scatter of the next, the first and the last beyond it).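

Formyl in place of hydrogen on the ring nitrogen gives a number 12.5 percentage points higher from compound 3 to compound 4 (beyond the scatter) and so shows that acetyl is not the only group at this position to go with a higher number than hydrogen. Hydrogen in place of methyl on the carbonyl carbon gives a number 9.4 percentage points lower from compound 1 to compound 4 (within the scatter) and so does not separate formyl from acetyl here. Methyl in place of chloro on an aromatic carbon gives a number 3.1 percentage points higher from compound 2 to compound 4 (within the scatter) and likewise leaves the two formyl compounds unseparated.

On these data alone, whether benzoyl or a longer chain such as propanoyl on this nitrogen would change the number remains open. Nothing measured here says why the number moves with these groups.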